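Amide aryl replacement on the shared core: compound 3

The source may hold more compounds than are shown below. What is called first, only, known or untested is meant among the compounds shown, and "the series" means these compounds.

Measured so far:
compound 1, `CN1[C@@H]2c3[nH]c4ccccc4c3C[C@H]1[C@H](C#N)N1[C@@H](CNC(=O)c3ccc(Cl)cc3)c3[nH]c4ccccc4c3C[C@@H]21`: 230 nM
compound 2, `CN1[C@@H]2c3[nH]c4ccccc4c3C[C@H]1[C@H](C#N)N1[C@@H](CNC(=O)c3ccc(F)cc3)c3[nH]c4ccccc4c3C[C@@H]21`: 250 nM

In a functional assay on A2780 cells (Homo sapiens) for cytotoxicity, read by MTT assay, with a stated time of 72 h (a higher number here means a weaker inhibitor, a lower number a stronger inhibitor), compound 1 gives the lower of the two numbers, and compound 2 sits within the scatter of it. Going by the values given here, the single measured step, a 1.1-fold higher number from compound 1 to compound 2 (0.04 log units; within the scatter), exchanges one halogen for another on an aromatic carbon of the amide aryl group and changes nothing beyond the scatter. Compound 3, `CN1[C@@H]2c3[nH]c4ccccc4c3C[C@H]1[C@H](C#N)N1[C@@H](CNC(=O)c3cccc4c3CCCC4)c3[nH]c4ccccc4c3C[C@@H]21`, is not yet measured. It differs from compound 1 by 1,2,3,4-tetrahydronaphthalen-5-yl in place of 4-chlorophenyl on a carbonyl carbon. The halogen exchange does not address this change: it keeps the aryl ring otherwise as it is, whereas compound 3 loses the chlorine and gains a six-membered non-aromatic ring. The expectation therefore rests on compound 1 alone, with a wide range in either direction and no basis for a step beyond the scatter. Compound 3 is expected near 350 nM, between 100 nM and 1500 nM, which means an expected step of a 1.5-fold higher number from compound 1 to compound 3 (0.18 log units; within the scatter).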

Compound 3, half-maximal inhibitory concentration: 810 nM
The estimate for compound 3 lay 2.3-fold (0.36 log units) below the measured number, within the range that was stated.
By their numbers in this assay, from the lowest: compounds 1 and 2 (each within the scatter of the next); then compound 3.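

In this assay, 1,2,3,4-tetrahydronaphthalen-5-yl in place of 4-chlorophenyl on the carbonyl carbon gives a 3.5-fold higher number from compound 1 to compound 3 (0.55 log units; beyond the scatter), and in place of 4-fluorophenyl it gives a 3.2-fold higher number from compound 2 to compound 3 (0.51 log units; beyond the scatter). The position is therefore not indifferent to the group it carries: the halogen exchange alone gave only a 1.1-fold higher number from compound 1 to compound 2 (0.04 log units; within the scatter), whereas this replacement moves the number beyond the scatter, towards a weaker inhibitor, by a modest step. No measurement at hand accounts for this loss.

The change removes the halogen and adds a six-membered non-aromatic ring in one step, and the compounds shown leave open which of the two matters. Also open, going by these compounds, is how the series responds to plain phenyl, or to an aryl group bearing an amine or a carboxylic acid, on this carbonyl carbon.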